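Removing Fluorine from the Trifluoromethoxy Group of Compound 3

A few compounds are considered here, and "the series" means these few. Any claim that something is new, unique, unknown or untested is made for them only; others in the source may bear on it.

In a functional assay on COLO 205 cells (Homo sapiens) for antiproliferative activity, read by MTT assay (on this read-out higher numbers stand for weaker inhibition and lower numbers for stronger inhibition), compound 1 `C#CCN(c1nc2ccc(F)cc2s1)c1nc2ccc(OC)cc2s1` gives 30300 nM, compound 2 `COc1ccc2nc(N(Cc3cc(-c4ccc(SC(F)(F)F)cc4)no3)c3nc4ccc(F)cc4s3)sc2c1` gives 11100 nM, and compound 3 `COc1ccc2nc(N(Cc3cc(-c4ccc(OC(F)(F)F)cc4)no3)c3nc4ccc(F)cc4s3)sc2c1` gives 9940 nM. Compound 3 holds the lowest of the three numbers, yet its neighbour compound 2 sits within the scatter of it, so the two cannot be ordered; only compound 1 stands clearly apart with a higher number.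

Compound 4 `COc1ccc(-c2cc(CN(c3nc4ccc(F)cc4s3)c3nc4ccc(OC)cc4s3)on2)cc1` differs from compound 3 in a single place: methyl in place of trifluoromethyl on an oxygen on an aromatic ring. Read one bond further out, the same change turns trifluoromethoxy into methoxy, or 4-(trifluoromethoxy)phenyl into 4-methoxyphenyl.

Among the measured compounds shown here, no measured pair shows exactly this change. For the measured compounds named here, the one single-point step available, from compound 2 to compound 3, exchanged (trifluoromethyl)sulfanyl for trifluoromethoxy and gave a 1.1-fold lower number from compound 2 to compound 3 (0.05 log units; within the scatter), a shift inside the scatter. That step suggests the group at this outer end of the molecule has not so far moved the read-out much, but it does not cover the loss of all three fluorine atoms.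

The expectation is therefore a small step, if any, likely a modest rise in the number: compound 4 is estimated at 12000 nM, with a range from 5000 nM to 30000 nM. This estimate corresponds to an expected step of a 1.2-fold higher number from compound 3 to compound 4 (0.08 log units; within the scatter).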

Compound 4, half-maximal inhibitory concentration: 11400 nM
Compound 4: middle estimate off by 1.1-fold (0.02 log units), on the high side; the range from low to high includes it.
By their numbers in this assay, from the lowest: compounds 3, 2 and 4 (each within the scatter of the next); then compound 1.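

In this assay, the loss of all three fluorine atoms, with methyl in place of trifluoromethyl on an oxygen on an aromatic ring, gives a 1.1-fold higher number from compound 3 to compound 4 (0.06 log units; within the scatter) and so leaves compound 3 and compound 4 impossible to order. Methoxy in place of (trifluoromethyl)sulfanyl on an aromatic carbon likewise gives a 1.0-fold higher number from compound 2 to compound 4 (0.01 log units; within the scatter) and so extends the same picture: among compound 2, compound 3 and compound 4, these three groups on the aromatic ring cannot be told apart, whether or not they carry fluorine. No measurement is available here that could explain this lack of a clear difference.

Open, as far as these compounds go, is whether a different kind of group on this aromatic carbon, such as an amine or a carboxylic acid, or a longer chain on the oxygen, such as ethoxy or butoxy, would separate clearly from these three. Also open, from the compounds shown here alone, is whether any group at this end can give a number clearly lower than that of compound 3, which stands at 9940 nM in this assay, or whether changes elsewhere in the molecule would be needed for that.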